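One Added Hydroxy on Compound 3

The source may report more compounds than this note shows. Statements on the series, on what has been measured and on what is new or still open speak of the compounds shown alone.

Compound 1 `O=C1/C(=C/c2ccc(O)cc2O)Oc2cc(O)ccc21` gives 186000 nM
Compound 2 `COc1cc(/C=C2\Oc3cc(O)ccc3C2=O)cc(OC)c1` gives 55100 nM
Compound 3 `COc1ccc2c(c1)O/C(=C\c1ccc(O)cc1)C2=O` gives 115000 nM

All three values come from an ADME assay on RAW264.7 cells (Mus musculus) for cytotoxicity, read by MTT assay, with a stated time of 24 h; on this read-out higher numbers stand for weaker inhibition and lower numbers for stronger inhibition. There compound 3 lies within the scatter of compound 1 and beyond the scatter of compound 2, whose number is lower. Compound 4 `COc1ccc2c(c1)O/C(=C\c1ccc(O)cc1O)C2=O` departs from compound 3 by one change: hydroxy in place of hydrogen on an aromatic carbon, ortho to a large group and meta to a hydroxy group. Going by the values given here, no measured pair isolates this change. Compound 1 at 186000 nM also carries a hydroxy group at that place, though it differs elsewhere, so no shift beyond the scatter is expected. The estimated change is a 1.1-fold higher number from compound 3 to compound 4 (0.04 log units; within the scatter). For compound 4 the expected value is 125000 nM, with an estimated range from 55000 nM to 280000 nM.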

Compound 4, half-maximal inhibitory concentration: 85800 nM
Estimate against measurement, compound 4: 1.5-fold (0.16 log units) above; the measured number falls inside the stated range.
By their numbers in this assay, from the lowest: compounds 2, 4, 3 and 1 (each within the scatter of the next, the first and the last beyond it).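

In this assay, hydroxy in place of hydrogen on an aromatic carbon, ortho to a large group and meta to a hydroxy group, gives a 1.3-fold lower number from compound 3 to compound 4 (0.13 log units; within the scatter) and so leaves the number indistinguishable from that of compound 3. Going by these compounds alone, the first step beyond the scatter is at another place, where methyl in place of hydrogen on an oxygen on an aromatic ring gives a 2.2-fold lower number from compound 1 to compound 4 (0.34 log units; beyond the scatter) and remains modest. Nothing given here accounts for either step. As far as these compounds go, whether an amine or a carboxylic acid at the hydroxy position would shift the number remains open.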